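Swapping 3,5-dimethoxyphenyl for 2,4-dimethylphenyl

The source may report more compounds than this note shows. Statements on the series, on what has been measured and on what is new or still open speak of the compounds shown alone.

Three measured compounds share one core and differ in the group on a nitrogen. Compound 1 `COc1ccc(C(F)(F)F)cc1Nc1ncc(C(F)(F)F)c(N2Cc3cccc(N(C)S(C)(=O)=O)c3C2)n1` gives > 30000 nM in a functional assay on OVCAR-3 cells (Homo sapiens) for antiproliferative activity, read by spectrophotometry, with a stated time of 2 days (on this read-out higher numbers stand for weaker inhibition of growth and lower numbers for stronger inhibition of growth), as a limit of the assay, not a number. Compound 2 `Cc1cc(F)ccc1Nc1ncc(C(F)(F)F)c(N2Cc3cccc(N(C)S(C)(=O)=O)c3C2)n1` gives > 30000 nM in this assay as a limit too. Within the data shown here, compound 3 `COc1cc(Nc2ncc(C(F)(F)F)c(N3Cc4cccc(N(C)S(C)(=O)=O)c4C3)n2)cc(OC)c1` gives 630 nM as the only true number of the three.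

Compound 4 `Cc1ccc(Nc2ncc(C(F)(F)F)c(N3Cc4cccc(N(C)S(C)(=O)=O)c4C3)n2)c(C)c1` has not been measured. It carries 2,4-dimethylphenyl in place of 3,5-dimethoxyphenyl on a nitrogen on an aromatic ring, and the difference counts as 2,4-dimethylphenyl in place of 3,5-dimethoxyphenyl on a nitrogen on an aromatic ring with the core unchanged.

Among the measured compounds shown here, two measured steps bear on this swap. Putting 3,5-dimethoxyphenyl in place of 2-methoxy-5-(trifluoromethyl)phenyl gave an at least 47-fold lower number from compound 1 to compound 3 (1.67 log units; beyond the scatter) and putting it in place of 4-fluoro-2-methylphenyl gave an at least 47-fold lower number from compound 2 to compound 3 (1.67 log units; beyond the scatter) as the second large step. The remaining comparison is a step that the two limits leave unreadable from compound 1 to compound 2 and adds nothing on size.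

The entering group most resembles 4-fluoro-2-methylphenyl, so a large step in the reverse direction is expected. The expected result in this assay is a 32-fold higher number from compound 3 to compound 4 (1.50 log units; beyond the scatter) toward weaker inhibition of growth, and a report as a mere limit is quite possible. For compound 4 the estimated value is 20000 nM with an expected range from 3000 nM to 60000 nM in this measurement.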

Compound 4, concentration for 50% growth inhibition: > 30000 nM
Compound 4: a limit, no number; the forecaster's own chance of this, stated with the estimate: 60%; middle value at least 1.5-fold (0.17 log units) from the limit.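

Replacing 3,5-dimethoxyphenyl with 2,4-dimethylphenyl gives an at least 47-fold higher number from compound 3 to compound 4 (1.67 log units; beyond the scatter) in this assay, so this third change of the group on the nitrogen also ends in a loss of growth inhibition. Compound 1 and compound 2 each carry fluorine, as trifluoromethyl or fluoro, on this ring, whereas compound 4 has only two methyl groups there, so the loss among these compounds does not depend on a fluorine-bearing group. The steps among compound 1, compound 2 and compound 4 cannot be read, and the full size of the step to compound 4 stays unknown, because these compounds all stop at the same point: the limit of > 30000 nM in this assay, at which 3 of the 4 values shown sit.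

Compound 3 and compound 4 differ both in the kind of group and in its placement on the ring, so 2,4-dimethoxyphenyl and 3,5-dimethylphenyl would be needed to separate these two changes. From the compounds shown here alone, it also remains open whether 3,5-dimethoxyphenyl needs its methoxy groups at all, or whether an amine or a carboxylic acid in those places would still inhibit growth.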